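The source may hold more compounds than are shown below. What is called first, only, known or untested is meant among the compounds shown, and "the series" means these compounds.

Among the measured compounds shown here, compound 3 `C=CCCCCCCCC#CC#C/C=C/C(C)=O` stands lowest of the three numbers so far in a functional assay on SK-MEL-2 cells (Homo sapiens) for cytotoxicity (a lower number here means that less compound is needed, a higher number that more compound is needed for the effect), where compound 3 gives 1.5 ug/mL. Compound 2 `CCCCCCCC#CC#C/C=C\C(C)=O` gives 42.6 ug/mL, and compound 1 `C=CCCCCCCCC#CC#C/C=C\C(C)=O` gives 43.1 ug/mL. For the measured compounds named here, the one large step in the set is a 29-fold lower number from compound 1 to compound 3 (1.46 log units; beyond the scatter), which rests on the fact that compounds 1 and 3 differ only in the configuration as drawn and on nothing else in the structures.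

Compound 4 `CCCCCCCC#CC#C/C=C/C(C)=O` has not yet been measured. It differs from compound 3 as follows: hydrogen in place of vinyl on a saturated chain carbon, seven bonds along the chain from a triple-bonded carbon. The same change has already been measured once, on the pair with the other double-bond configuration: a 1.0-fold lower number from compound 1 to compound 2 (0.01 log units; within the scatter), a step that stays within the scatter. Going by the values given here, that is the only measured step bearing on the move from compound 3 to compound 4, and it gives no ground to expect a shift beyond the scatter in either direction in this assay.

For compound 4 the expected value is 1.5 ug/mL, with a range of 0.6 ug/mL to 4 ug/mL. The expected step is therefore no change at the digits printed from compound 3 to compound 4 (within the scatter).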

Compound 4, concentration for half-maximal effect: 1.4 ug/mL
The estimate for compound 4 lay 1.1-fold (0.03 log units) above the measured number; the measured number falls inside the stated range.
By their numbers in this assay, from the lowest: compounds 4 and 3 (each within the scatter of the next); then compounds 2 and 1 (each within the scatter of the next).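

The swap of vinyl for hydrogen on this saturated chain carbon now reads on both double-bond configurations in this assay, with a 1.1-fold lower number from compound 3 to compound 4 (0.03 log units; within the scatter), so the change leaves the number unmoved within the scatter on the E compounds as well as on the Z compounds. The agreement rests on two pairs: the same change on two cores in this assay, a 1.0-fold lower number (0.01 log units; within the scatter) from compound 1 to compound 2 and a 1.1-fold lower number (0.03 log units; within the scatter) from compound 3 to compound 4, 1.1-fold (0.02 log units) apart, within the scatter of two such steps. The large configuration step also recurs without the vinyl group, with a 30-fold lower number from compound 2 to compound 4 (1.48 log units; beyond the scatter), so the low numbers go with the double bond drawn E on both chains shown: the fact that compounds 2 and 4 differ only in the configuration as drawn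

Whether an amine or a carboxylic acid on this chain carbon would also leave the number in place stays open, since only vinyl and hydrogen are shown there. Also open, on these data alone, is whether a longer chain would keep the same gap between the E and Z compounds.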